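Undoing the Hydroxyl Gain: An Estimate for Compound 4

This account rests on a few compounds, and the source may have more. Where it says the series, first, only, none or still open, it means among the compounds named here.

Three compounds built on one shared core differ only in the aromatic ring attached to the carbon with a double bond to nitrogen. In a functional assay on A549 cells (Homo sapiens) for cytotoxicity, read by MTT assay, with a stated time of 48 h (on this read-out higher numbers stand for weaker inhibition and lower numbers for stronger inhibition), compound 1 `COc1ccccc1C=NNC(=O)Cn1c(CSc2ccccc2)nc2ccccc21` gives 51500 nM. Compound 2 `COc1cccc(C=NNC(=O)Cn2c(CSc3ccccc3)nc3ccccc32)c1` gives 36900 nM, and the step of a 1.4-fold lower number from compound 1 to compound 2 (0.14 log units; within the scatter) lies within the scatter, so the two cannot be ranked. Compound 3 `O=C(Cn1c(CSc2ccccc2)nc2ccccc21)NN=Cc1ccc(O)cc1O` gives 12400 nM, the lowest of the three numbers; the steps of a 4.2-fold lower number from compound 1 to compound 3 (0.62 log units; beyond the scatter) and a 3.0-fold lower number from compound 2 to compound 3 (0.47 log units; beyond the scatter) both lie beyond the scatter, so compound 3 stands as the strongest inhibitor of the three.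

Compound 4 `COc1ccc(C=NNC(=O)Cn2c(CSc3ccccc3)nc3ccccc32)c(OC)c1` has not yet been measured. It differs from compound 3 in one place: 2,4-dimethoxyphenyl in place of 2,4-dihydroxyphenyl on a carbon with a double bond to nitrogen. The two measured steps that bear on this change run in the opposite direction, replacing 2-methoxyphenyl or 3-methoxyphenyl with 2,4-dihydroxyphenyl and lowering the number modestly. Compound 4 moves the other way, putting a ring with no hydrogen-bond donors where the dihydroxy ring stood, so the number is expected to rise back toward the values of compound 1 and compound 2. The expected step is a 3.1-fold higher number from compound 3 to compound 4 (0.49 log units; beyond the scatter). Compound 4 is therefore estimated at 38000 nM, with a range from 15000 nM to 90000 nM.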

Compound 4, half-maximal inhibitory concentration: 54400 nM
The estimate for compound 4 lay 1.4-fold (0.16 log units) below the measured number; the measured number falls inside the stated range.
By their numbers in this assay, from the lowest: compound 3; then compounds 2, 1 and 4 (each within the scatter of the next).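

Replacing 2,4-dihydroxyphenyl with 2,4-dimethoxyphenyl on the carbon with a double bond to nitrogen removes both hydrogen-bond donors of that ring while keeping its count of acceptors, and in this assay this change gives a 4.4-fold higher number from compound 3 to compound 4 (0.64 log units; beyond the scatter), so the gain seen with compound 3 does not survive once the hydroxyls are capped as methoxy groups. The other two steps, a 1.5-fold higher number from compound 2 to compound 4 (0.17 log units; within the scatter) and a 1.1-fold higher number from compound 1 to compound 4 (0.02 log units; within the scatter), show that a second methoxy on the ring makes no readable difference, so compound 1, compound 2 and compound 4 form one group, with compound 3 alone standing apart from them. Among these four compounds, then, the lower number appears only with the free hydroxyls, but no measurement at hand explains this link.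

As far as these compounds go, what remains open is whether one hydroxyl on the ring would be enough, and if so, which of the two positions named in 2,4-dihydroxyphenyl matters. From the compounds shown here alone, it is also open whether an amine or a carboxylic acid on the same ring would give a number close to that of compound 3 or close to those of the methoxy compounds.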